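The source may report more compounds than this note shows. Statements on the series, on what has been measured and on what is new or still open speak of the compounds shown alone.

Measured in a functional assay on HeLa cells (Homo sapiens) for cytotoxicity, read by MTT assay, with a stated time of 72 h; on this read-out higher numbers stand for weaker inhibition and lower numbers for stronger inhibition:
compound 1 `Nn1c(SCc2ccccc2)nnc1-c1c[nH]c2ccccc12`: 2300 nM
compound 2 `Nn1c(SCc2ccccc2[N+](=O)[O-])nnc1-c1c[nH]c2ccccc12`: 2520 nM

Compound 1 and compound 2 lie within the scatter of each other, as a 1.1-fold higher number from compound 1 to compound 2 (0.04 log units; within the scatter) shows; neither stands apart. Compound 3 `Nn1c(SCc2cccc([N+](=O)[O-])c2)nnc1-c1c[nH]c2ccccc12` is unmeasured and differs from compound 1 by nitro in place of hydrogen on an aromatic carbon. Going by the values given here, the only step that bears on it is a 1.1-fold higher number from compound 1 to compound 2 (0.04 log units; within the scatter), also nitro for hydrogen on that ring, which stayed within the scatter. No step beyond the scatter is therefore expected in this assay, a 1.1-fold higher number from compound 1 to compound 3 (0.04 log units; within the scatter). Compound 3 is estimated at 2500 nM, with a range of 1200 nM to 5500 nM.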

Compound 3, half-maximal inhibitory concentration: 400 nM
For compound 3 the middle estimate is 6.3-fold (0.80 log units) above the measured one; measured number outside the range, below it.
By their numbers in this assay, from the lowest: compound 3; then compounds 1 and 2 (each within the scatter of the next).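

In this assay nitro in place of hydrogen, meta to a large group, gives a 5.8-fold lower number from compound 1 to compound 3 (0.76 log units; beyond the scatter) while the same group elsewhere on that ring in compound 2 gives a 1.1-fold higher number from compound 1 to compound 2 (0.04 log units; within the scatter) and stays within the scatter. The outcome of this change therefore depends on where the nitro sits on the ring, not on its presence alone, although the step is modest and rests on one pair. Nothing available accounts for the difference. Going by these compounds, whether an amine, a methoxy group or a chlorine atom on the same carbon gives a similar step remains open.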